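The source may report more compounds than this note shows. Statements on the series, on what has been measured and on what is new or still open speak of the compounds shown alone.

Measured compounds:
- compound 1, `Nc1nc(Cl)c2ncn(Cc3ccccc3CCl)c2n1`: in a functional assay on NCI-H23 cells (Homo sapiens) for cytotoxicity, read by sulforhodamine B assay, with a stated time of 48 h (a lower number here means a stronger inhibitor of growth, a higher number a weaker inhibitor of growth), compound 1 gives 3020 nM
- compound 2, `Nc1nc(Cl)c2ncn(Cc3ccc(CCl)cc3)c2n1`: in this assay compound 2 gives 12000 nM

Compound 1 holds the lowest of the two numbers; compound 2 sits a clear distance above it, beyond the usual scatter. Going by the values given here, no step between compounds that differ in a single place is available, so nothing yet shows how a change at the core translates into growth inhibition.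

The next compound, compound 3, `ClCc1ccccc1Cn1cnc2c(Cl)nc(Cl)nc21`, differs from compound 1 by chloro in place of amino on an aromatic carbon. The place is on an aromatic carbon of a six-membered aromatic ring with two nitrogen atoms, between two ring nitrogen atoms, meta to a chloro group. Among the compounds with values here, with no comparable step on record, the expected step in this assay is small, likely none beyond the scatter, with a slight lean toward a higher number. Compound 3 is therefore estimated at 4000 nM, in the range 1000 nM to 16000 nM, an expected step of a 1.3-fold higher number from compound 1 to compound 3 (0.12 log units; within the scatter).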

Compound 3, concentration for 50% growth inhibition: 1510 nM
For compound 3 the middle estimate is 2.6-fold (0.42 log units) above the measured one, within the range that was stated.
By their numbers in this assay, from the lowest: compounds 3 and 1 (each within the scatter of the next); then compound 2.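

In this assay, chloro in place of amino on an aromatic carbon between two ring nitrogen atoms gives a 2.0-fold lower number from compound 1 to compound 3 (0.30 log units; within the scatter) and so stays within the scatter. This first single-place step in the series shows that the amino group is not needed at this place to keep growth inhibition at the level of compound 1, even though the hydrogen-bond donor counted on amino is absent from chloro. Nothing on record accounts for this outcome or connects it to a property of either group.

On these data alone, whether a methoxy group, a methylamino group or plain hydrogen at the same place would hold that level remains open. Also open, as far as these compounds go, is whether the same exchange of amino for chloro would give a similar step on compound 2.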